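Moving the chloro from one ring position to another

This account rests on a few compounds, and the source may have more. Where it says the series, first, only, none or still open, it means among the compounds named here.

Compound 1 (`Cn1c(=O)c(=O)n(C2CCCC2)c2nc(N/N=C/c3ccc(Cl)cc3)ncc21`) gives 8420 nM in a functional assay on PC-3 cells (Homo sapiens) for antiproliferative activity, read by MTT assay (on this read-out higher numbers stand for weaker inhibition and lower numbers for stronger inhibition), the lowest number of the three measured compounds. Compound 2 (`Cn1c(=O)c(=O)n(C2CCCC2)c2nc(N/N=C/c3ccc(O)c(F)c3)ncc21`) gives 85200 nM, and compound 3 (`CSc1ccc(/C=N/Nc2ncc3c(n2)n(C2CCCC2)c(=O)c(=O)n3C)cc1`) gives 21000 nM. Both changes away from compound 1 raise the number: a 10-fold higher number from compound 1 to compound 2 (1.01 log units; beyond the scatter) and a 2.5-fold higher number from compound 1 to compound 3 (0.40 log units; beyond the scatter), while a 4.1-fold lower number from compound 2 to compound 3 (0.61 log units; beyond the scatter).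

Compound 4 (`Cn1c(=O)c(=O)n(C2CCCC2)c2nc(N/N=C/c3ccccc3Cl)ncc21`) keeps every atom of compound 1 but joins them differently: 2-chlorophenyl in place of 4-chlorophenyl on a carbon with a double bond to nitrogen. For the measured compounds named here, no measured pair shows the chloro moved to another ring position, so the two measured steps bear on it only indirectly. They show that the 4-chlorophenyl of compound 1 is the best of the aryl groups tried, and that replacing it with a different group costs between a modest and a large amount. Moving the chloro rather than swapping it is a smaller change than either of those, so a modest weakening is expected, though the scatter could hide it. Compound 4 is expected to give 15000 nM in this assay, between 5000 nM and 45000 nM, a step of a 1.8-fold higher number from compound 1 to compound 4 (0.25 log units; within the scatter).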

Compound 4, half-maximal inhibitory concentration: 16300 nM
For compound 4 the middle estimate is 1.1-fold (0.04 log units) below the measured one; low and high end bracket the measured number.
By their numbers in this assay, from the lowest: compounds 1, 4 and 3 (each within the scatter of the next, the first and the last beyond it); then compound 2.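

In this assay, for the compounds shown here, compound 4 gives the first direct look at where the chloro sits on the ring: 2-chlorophenyl in place of 4-chlorophenyl gives a 1.9-fold higher number from compound 1 to compound 4 (0.29 log units; within the scatter), so these two placements cannot be told apart here. Compound 4 also cannot be separated from the 4-(methylsulfanyl)phenyl compound, with a 1.3-fold lower number from compound 3 to compound 4 (0.11 log units; within the scatter), whereas the 3-fluoro-4-hydroxyphenyl compound remains clearly apart, with a 5.2-fold lower number from compound 2 to compound 4 (0.72 log units; beyond the scatter); among these four compounds, compound 2 is the only one whose steps to all the others lie beyond the scatter. No measurement at hand gives a reason for these numbers.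

The compounds shown leave open whether a bromo in place of the chloro, on either ring position, would stay within the scatter of compound 1 and compound 4. They also leave open whether an amine or a carboxylic acid on the same ring would fall close to these compounds or nearer to compound 2, which would help show how much of the gap to compound 2 depends on the group chosen.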